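Swapping the benzyl cap for a furan ring

This account rests on a few compounds, and the source may have more. Where it says the series, first, only, none or still open, it means among the compounds named here.

Compound 1 `COc1cccc(CNCCCNc2ccnc3cc(Oc4ccc(Cl)cc4)ccc23)c1O` carries a 2-hydroxy-3-methoxybenzyl group on its amine chain, and in an ADME assay on HepG2 cells (Homo sapiens) for cytotoxicity, read by luminescence, CellTiter-Glo and ATP content, with a stated time of 72 h (a higher number here means that more compound is needed for the effect, a lower number that less compound is needed), compound 1 gives 5700 nM. Of the two numbers measured, this is the lower one; the nearest is compound 2 `COc1cccc(CNCCCNc2ccnc3cc(Oc4cccc(N(C)C)c4)ccc23)c1O`, which in this assay gives 7300 nM. The step of a 1.3-fold higher number from compound 1 to compound 2 (0.11 log units; within the scatter) changes only the aryl ether on the far side of the shared core, and it lies within the scatter.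

Compound 3 `Clc1ccc(Oc2ccc3c(NCCCNCc4ccco4)ccnc3c2)cc1` is the unmeasured partner. Its change from compound 1 is furan-2-yl in place of 2-hydroxy-3-methoxyphenyl on a saturated chain carbon bound to an amine nitrogen. For the measured compounds named here, no measured step touches this end of the molecule; the only step known, from compound 1 to compound 2, sits elsewhere and was within the scatter. There is therefore no measured basis to expect a move beyond the scatter in this assay for compound 3, and the step of a 1.1-fold higher number from compound 1 to compound 3 (0.02 log units; within the scatter) is expected to stay small.

For compound 3 the estimate in this assay is 6000 nM, with a range from 2500 nM to 15000 nM.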

Compound 3, half-maximal effective concentration: 7800 nM
Compound 3: the middle estimate sits 1.3-fold (0.11 log units) below what was measured; low and high end bracket the measured number.
By their numbers in this assay, from the lowest: compounds 1, 2 and 3 (each within the scatter of the next).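

In this assay, for the compounds shown here, the step from the benzyl end to the furan end is a 1.4-fold higher number from compound 1 to compound 3 (0.14 log units; within the scatter) and gives the first measured look at this end of the molecule, since the earlier step touched only the aryl ether. Furan-2-yl in place of 2-hydroxy-3-methoxyphenyl is a sizeable exchange on paper, going from 9 heavy atoms to 5, from a six-membered aromatic ring of carbon only to a five-membered one with 1 hetero atom, and from 1 hydrogen-bond donor to 0, yet the number stays within the scatter, so for this pair neither the hydroxy and methoxy groups nor the larger ring are needed to keep the read-out where it is. Nothing at hand explains why the read-out holds across this change. What the compounds shown leave open is whether this tolerance extends to other groups on the same carbon, such as a plain phenyl, a pyridine ring, a saturated piperidine ring or a carboxylic acid. Also open, on these data alone, is whether a longer chain, or furan-2-yl combined with the 3-(dimethylamino)phenyl ether of compound 2, would keep the number within the scatter as well.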